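Group on sulfur: from compound 2 to compound 4

This account rests on a few compounds, and the source may have more. Where it says the series, first, only, none or still open, it means among the compounds named here.

Measured in a functional assay on MV4-11 cells (Homo sapiens) for inhibition, read by resazurin assay, with a stated time of 72 h (on this read-out higher numbers stand for weaker inhibition of growth and lower numbers for stronger inhibition of growth), so far
Compound 1 `COc1ccc(Nc2nccc(-c3c[nH]c4ccccc34)n2)c(OC(F)F)c1` gives 4770 nM
Compound 2 `COc1ccc(Nc2nccc(-c3sc(SC(C)C)nc3C)n2)c(OC)c1` gives 5670 nM
Compound 3 `COc1ccc(Nc2nccc(-c3c[nH]c4ccccc34)n2)c(OC)c1` gives 600 nM

Compound 2 and compound 1 lie within the scatter of each other, and the value of compound 3 is clearly lower than both. Compound 2 therefore sits at the weak end of this small set.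

The next compound is compound 4 `COc1ccc(Nc2nccc(-c3sc(SCCCN(C)C)nc3C)n2)c(OC)c1`, which carries 3-(dimethylamino)propyl in place of isopropyl on a sulfur and awaits measurement.

Among the compounds with values here, no measured step touches the group on sulfur. Within the data shown here, the only step available is an 8.0-fold lower number from compound 1 to compound 3 (0.90 log units; beyond the scatter) and it concerns methyl in place of difluoromethyl on an oxygen on an aromatic ring, on the core of compound 1 rather than that of compound 2. It gives a rough scale for one change in this set but no direction for this one. A modest step of no greater size is expected. The lean toward a lower number rests only on compound 3 at 600 nM showing that lower values occur in this set.

The expected change in this assay is a 2.8-fold lower number from compound 2 to compound 4 (0.45 log units; beyond the scatter) as a loose estimate. In this assay compound 4 is estimated at 2000 nM with a range from 500 nM to 7000 nM expected.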

Compound 4, concentration for 50% growth inhibition: 370 nM
Estimate against measurement, compound 4: 5.4-fold (0.73 log units) above; the whole stated range lies above it.
By their numbers in this assay, from the lowest: compounds 4 and 3 (each within the scatter of the next); then compounds 1 and 2 (each within the scatter of the next).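

In this assay, within the data shown here, 3-(dimethylamino)propyl in place of isopropyl on a sulfur gives a 15-fold lower number from compound 2 to compound 4 (1.19 log units; beyond the scatter) and is the first measured step at this position, which until now was known only through the isopropyl compound. The position is therefore not silent: a change on this sulfur, whose other neighbour is an aromatic carbon, can shift growth inhibition by a large step on the core of compound 2. The entering group is both a longer chain and a carrier of a nitrogen, so these two differences change together and this single step cannot tell them apart. No measurement at hand gives a cause for the size of this step.

An unbranched pentyl chain with no nitrogen, or a shorter 2-(dimethylamino)ethyl chain on the same sulfur, would be needed to separate chain length from the amine. As far as these compounds go, it also remains open whether methyl in place of difluoromethyl on an oxygen, read so far only as an 8.0-fold lower number from compound 1 to compound 3 (0.90 log units; beyond the scatter) on the other core, carries over to the core of compound 4.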